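The source may report more compounds than this note shows. Statements on the series, on what has been measured and on what is new or still open speak of the compounds shown alone.

Measured so far:
- compound 1 `O=C(Nc1ccc2scnc2c1)C1CCCN(Cc2ccc(F)c(F)c2)C1`: > 20000 nM, a limit
- compound 2 `O=C(Nc1ccc(-c2cscn2)cc1)C1CCCN(Cc2cccc(OC(F)(F)F)c2)C1`: > 20000 nM, a limit
- compound 3 `O=C(Nc1ccc(-c2ccccc2)cc1)C1CCCN(Cc2ccc(F)c(F)c2)C1`: 2580 nM

For the measured compounds named here, in a functional assay on A-375 cells (Homo sapiens) for antiproliferative activity (on this read-out higher numbers stand for weaker inhibition and lower numbers for stronger inhibition), compound 3 is the only compound with a number, 2580 nM. Compound 1 and compound 2 both rest on (the limit of > 20000 nM in this assay, at which 2 of the 3 values shown sit).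

Next is compound 4 `O=C(Nc1ccc(-c2ncc[nH]2)cc1)C1CCCN(Cc2ccc(F)c(F)c2)C1`, with 1H-imidazol-2-yl in place of phenyl on an aromatic carbon. Going by the values given here, no measured step isolates this change.

The expectation of weaker inhibition rests on compound 2, which also carries a five-membered aromatic ring with hetero atoms but differs elsewhere too, and gives > 20000 nM, a limit. The expected step is a 3.1-fold higher number from compound 3 to compound 4 (0.49 log units; beyond the scatter), beyond the usual scatter. For compound 4 the estimated value is 8000 nM, with an expected range of 2500 nM to 20000 nM.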

Compound 4, half-maximal inhibitory concentration: 19000 nM
For compound 4 the middle estimate is 2.4-fold (0.38 log units) below the measured one; the measured number falls inside the stated range.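

At the aromatic carbon para to a large group, the series now has its first change read in isolation: 1H-imidazol-2-yl in place of phenyl gives a 7.4-fold higher number from compound 3 to compound 4 (0.87 log units; beyond the scatter) in this assay. With the rest of the molecule held constant, phenyl is clearly favoured over this ring at this position. Compound 4 still gives a number, but one close to the ceiling of the read-out: the limit of > 20000 nM in this assay, at which 2 of the 4 values shown sit.

The compounds shown do not separate ring size from the ring nitrogens. A pyridyl or a fluorophenyl group at this place, or a methyl on the imidazole nitrogen, would bear on that question.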